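The source may report more compounds than this note shows. Statements on the series, on what has been measured and on what is new or still open speak of the compounds shown alone.

Measured so far:
compound 1, `O=C(O)[C@@H]1CCCN1C(=O)CN(c1nc(Cl)nc2[nH]cnc12)C1CC1`: 31.5%
compound 2, `C[C@@H](O)[C@H](NC(=O)CN(c1nc(Cl)nc2[nH]cnc12)C1CC1)C(=O)O`: 18.6%
compound 3, `CC(C)[C@H](NC(=O)CN(c1ncnc2c1ncn2C1CCCCO1)C1CC1)C(=O)OCc1ccccc1`: 21.8%

In a functional assay on the whole organism (Tail, strain ICR) with Mus musculus as the target, in the tail flick test, with a stated time of 30 min, at a dose of 25 umol/kg by the oral route (a higher number here means a stronger effect of the compound at the dose given, a lower number a weaker effect), compound 2 stands at the low end of the three numbers. Its gap to compound 1 is the only one that counts as a real step: a number 12.9 percentage points lower from compound 1 to compound 2 (beyond the scatter). Compound 3 gives 21.8%, and the gap between compound 2 and compound 3 lies within the usual scatter, so no order between these two can be read from the data.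

Compound 4, `O=C(O)C[C@H](NC(=O)CN(c1nc(Cl)nc2[nH]cnc12)C1CC1)C(=O)O`, is to be measured in this assay. It differs from compound 2 as follows: carboxymethyl in place of 1-hydroxyethyl on a saturated chain carbon bound to an amide-type nitrogen and a carbonyl carbon

Within the data shown here, only one measured step exists, and it concerns a different change on the carbonyl carbon, the exchange of a ring for an open chain, not the group on the saturated chain carbon bound to the amide-type nitrogen and the carbonyl carbon. It therefore gives no guide to the size or direction of the present change. Nothing in the series points to a step beyond the scatter, so the expectation for compound 4 is a number close to that of compound 2, with the estimated step of a number 1.4 percentage points higher from compound 2 to compound 4 (within the scatter). Compound 4 is estimated at 20%, in the range 6% to 34%.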

Compound 4, a percentage reported as activity, at one dose (the size of the read-out at that dose, not a potency): 19.9%
The estimate for compound 4 lay 0.1 percentage points above the measured number, within the range that was stated.
By their numbers in this assay, from the lowest: compounds 2, 4, 3 and 1 (each within the scatter of the next, the first and the last beyond it).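

Among these compounds, on the saturated chain carbon bound to an amide-type nitrogen and a carbonyl carbon, carboxymethyl in place of 1-hydroxyethyl in this assay gives a number 1.3 percentage points higher from compound 2 to compound 4 (within the scatter) at the single dose and time tested, the first reading of an exchange at this place. The group that leaves carries a defined stereocentre and the group that enters has a double bond outside aromatic rings, while the two have the same counts of hydrogen-bond donors and acceptors, and compound 2 and compound 4 cannot be told apart by this read-out. No measurement at hand offers an account of this result.

The compounds shown leave open whether an aminomethyl group, a plain methyl group or a longer chain ending in a phenyl ring at this same place would give a step beyond the scatter. Also open, from the compounds shown here alone, is whether the closeness of compound 2 and compound 4 would hold at other doses or at other times after dosing.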